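This account rests on a few compounds, and the source may have more. Where it says the series, first, only, none or still open, it means among the compounds named here.

Measured compounds and their values in the cytotoxicity read-out:

compound 1 `Cc1ccc(-n2ccnc2SCC(=O)Nc2ccccc2Cl)cc1` — 33700 nM
compound 2 `O=C(CSc1nccn1-c1cccc2ccccc12)Nc1ccccc1F` — 34700 nM
compound 3 `O=C(CSc1nccn1-c1cccc2ccccc12)Nc1ccccc1Br` — 30500 nM

All three numbers come from an ADME assay on MT4 cells (Homo sapiens) for cytotoxicity, read by MTT assay; on this read-out higher numbers stand for lower toxicity in this test and lower numbers for higher toxicity in this test. Compound 3 lies within the scatter of both other compounds: against compound 3, compound 1 gives 33700 nM and compound 2 gives 34700 nM, so the three cannot be ordered. Among the compounds with values here, the single measured step that swaps one group for another on the same aromatic carbon, a 1.1-fold lower number from compound 2 to compound 3 (0.06 log units; within the scatter), is itself within the scatter.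

Compound 4 `O=C(CSc1nccn1-c1cccc2ccccc12)Nc1ccccc1[N+](=O)[O-]` has not yet been measured in this assay. It differs from compound 3 as follows: nitro in place of bromo on an aromatic carbon. Within the data shown here, no measured step exchanges a halogen for a nitro group, so the only step that bears on this change is the halogen-for-halogen swap between compound 2 and compound 3, and that step was within the scatter. Against that background no step beyond the scatter is expected in this assay, in either direction; the estimated step is a 1.0-fold higher number from compound 3 to compound 4 (0.02 log units; within the scatter). Compound 4 is accordingly expected to give about 32000 nM, with a likely range from 15000 nM to 70000 nM; a limit value rather than a number is also possible in this read-out.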

Compound 4, half-maximal cytotoxic concentration: 28800 nM
Estimate against measurement, compound 4: 1.1-fold (0.05 log units) above; low and high end bracket the measured number.
By their numbers in this assay, from the lowest: compounds 4, 3, 1 and 2 (each within the scatter of the next).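

Up to now, the only step at this aromatic carbon exchanged one halogen for another. The 2-bromophenyl to 2-nitrophenyl change (a 1.1-fold lower number from compound 3 to compound 4 (0.02 log units; within the scatter)) and the exchange of fluoro for nitro (a 1.2-fold lower number from compound 2 to compound 4 (0.08 log units; within the scatter)) show that in this assay the number also holds when a non-halogen group sits ortho to a large group. Nitro brings three heavy atoms and two hydrogen-bond acceptors where bromo brings one heavy atom and no acceptor, yet this difference in make-up leaves compound 2, compound 3 and compound 4 unresolved in this read-out, so fluoro, bromo and nitro cannot be ordered at this carbon. Nothing available here accounts for the closeness of these numbers.

On these data alone, it remains open whether a group of another kind at this carbon, such as an amine, a carboxylic acid or a longer chain, would give a step beyond the scatter. Also open, as far as these compounds go, is whether nitro would behave the same way on another carbon of this ring or on the core of compound 1.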